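Methyl in Place of Chloro: An Expectation for Compound 4

This account rests on a few compounds, and the source may have more. Where it says the series, first, only, none or still open, it means among the compounds named here.

Compound 1 `Cc1ccccc1C(=O)Nc1sc2c(c1C(N)=O)CCN(C(=S)Nc1ccccc1Cl)C2` gives 35300 nM in a functional assay on HeLa cells (Homo sapiens) for antiproliferative activity, with a stated time of 24 h; a lower number here means a stronger inhibitor, a higher number a weaker inhibitor. Compound 2 `COc1ccccc1C(=O)Nc1sc2c(c1C(N)=O)CCN(C(=S)Nc1ccccc1Cl)C2` reaches only a limit of this assay, > 50000 nM. Compound 3 `Cc1ccc(C(=O)Nc2sc3c(c2C(N)=O)CCN(C(=S)Nc2ccccc2Cl)C3)cc1` gives 26300 nM in this assay.

Among the two plain numbers, compound 1 stands highest; its nearest neighbour is compound 3, with a 1.3-fold lower number from compound 1 to compound 3 (0.13 log units; within the scatter). Compound 4 `Cc1ccccc1NC(=S)N1CCc2c(sc(NC(=O)c3ccccc3C)c2C(N)=O)C1` differs from compound 1 by methyl in place of chloro on an aromatic carbon. The measured steps, an at least 1.4-fold higher number from compound 1 to compound 2 (0.15 log units; that floor lies within the scatter) and an at least 1.9-fold lower number from compound 2 to compound 3 (0.27 log units; that floor lies within the scatter), all alter the ring on the carbonyl carbon, not the ring that carries the chloro, so none of them speaks directly to this change; each stayed within the scatter. A step no larger than the scatter is therefore expected. Compound 4 is estimated at 35000 nM, between 15000 nM and 80000 nM, that is a 1.0-fold lower number from compound 1 to compound 4 (0.00 log units; within the scatter).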

Compound 4, half-maximal inhibitory concentration: > 50000 nM
Compound 4 was reported as a limit; the forecaster's own chance of this, stated with the estimate: 25%; middle value at least 1.4-fold (0.15 log units) away from the limit.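

Unlike the earlier compounds, compound 4 alters the 2-chlorophenyl ring itself, and in this assay its value is a limit, not a number. Going from 2-chlorophenyl to 2-methylphenyl gives an at least 1.4-fold higher number from compound 1 to compound 4 (0.15 log units; that floor lies within the scatter) and so shows neither a gain from methyl at this position nor a loss beyond the scatter. The real size of the step stays unknown because the read-out ends at a limit: the limit of > 50000 nM in this assay, at which 2 of the 4 values shown sit.

As far as these compounds go, whether an amine or a carboxylic acid in place of the chloro would give a lower number than compound 1 stays open. Also open, from the compounds shown here alone, is whether methyl in place of chloro would read differently with the 4-methylphenyl of compound 3.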